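Methylpiperazine in place of piperidine on the chain

This account rests on a few compounds, and the source may have more. Where it says the series, first, only, none or still open, it means among the compounds named here.

The series is followed in a functional assay on A549 cells (Homo sapiens) for antiproliferative activity, read by MTT assay, with a stated time of 72 h; a higher number here means a weaker inhibitor, a lower number a stronger inhibitor. Among the compounds with values here, compound 1 `COc1ncc(-c2ccc3nc(NC(=O)NCCN4CCCCC4)sc3c2)cc1NS(=O)(=O)c1ccc(F)cc1` gives 330 nM, the lowest of the two numbers so far. Within the data shown here, compound 2 `CCN(CC)CCNC(=O)Nc1nc2ccc(-c3cnc(Cl)c(NS(=O)(=O)c4ccc(F)cc4)c3)cc2s1` gives 5260 nM, a far higher number than compound 1 and beyond the scatter; no single-site step links the two, so only their values are compared. Compound 3 `COc1ncc(-c2ccc3nc(NC(=O)NCCN4CCN(C)CC4)sc3c2)cc1NS(=O)(=O)c1ccc(F)cc1` differs from compound 1 by 4-methylpiperazin-1-yl in place of piperidin-1-yl on a saturated chain carbon, two bonds along the chain from an amide-type nitrogen. Among the measured compounds shown here, no measured step of this kind exists in the set. The step is expected to stay within the scatter, leaning if anything toward a slightly higher number, estimated as a 1.3-fold higher number from compound 1 to compound 3 (0.10 log units; within the scatter). For compound 3 the estimate is 420 nM, with a range from 150 nM to 1200 nM.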

Compound 3, half-maximal inhibitory concentration: 550 nM
Compound 3: the middle estimate sits 1.3-fold (0.12 log units) below what was measured; low and high end bracket the measured number.
By their numbers in this assay, from the lowest: compounds 1 and 3 (each within the scatter of the next); then compound 2.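

In this assay, within the data shown here, the first single-site step reads a 1.7-fold higher number from compound 1 to compound 3 (0.22 log units; within the scatter) and so does not separate 4-methylpiperazin-1-yl from piperidin-1-yl on this saturated chain carbon. The position therefore takes the second ring nitrogen and its methyl group with no shift beyond the scatter. Nothing at hand bears on a cause for this result.

Still open, on these data alone, is whether a morpholine ring or a dimethylamino group at this place would give a similar number. Also open, as far as these compounds go, is whether a longer chain carrying the same ring would do so.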